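A few compounds are considered here, and "the series" means these few. Any claim that something is new, unique, unknown or untested is made for them only; others in the source may bear on it.

Compound 1 `COc1ccc(/C=C2\CCCc3ccccc3C2=O)cc1`: 1600 nM
Compound 2 `O=C1CCCCC/C1=C\c1cccc(Br)c1`: 24100 nM

Both compounds were tested in a functional assay on P388 cells (Mus musculus) for inhibition; a higher number here means a weaker inhibitor, a lower number a stronger inhibitor. Compound 2 has the higher of the two numbers at 24100 nM, making it the weaker inhibitor, and its gap to compound 1 lies beyond the scatter. Compound 3 `O=C1CCCCC/C1=C\c1cccc([N+](=O)[O-])c1` has nitro in place of bromo on an aromatic carbon. Going by the values given here, no measured pair shows this exchange, so only a cautious expectation is possible. The estimated step of a 1.7-fold lower number from compound 2 to compound 3 (0.24 log units; within the scatter) in this assay is small, slightly towards a lower number, and is not expected to exceed the scatter. Compound 3 is estimated at 14000 nM, with an expected range of 4000 nM to 45000 nM.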

Compound 3, half-maximal inhibitory concentration: 23600 nM
Compound 3: the middle estimate sits 1.7-fold (0.23 log units) below what was measured; measured number inside the range.
By their numbers in this assay, from the lowest: compound 1; then compounds 3 and 2 (each within the scatter of the next).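

In this assay, nitro in place of bromo on this aromatic carbon gives a 1.0-fold lower number from compound 2 to compound 3 (0.01 log units; within the scatter), so the two compounds cannot be told apart. At this position, then, a group with hydrogen-bond acceptors reads the same as bromo, which has none. No available measurement explains this result. As far as these compounds go, whether an amine or a carboxylic acid on this same carbon would also read level with these two remains open. So does whether this exchange would read alike on the core of compound 1.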